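Aryl Swap on a Urea Side Chain: Expectation for Compound 4

This account rests on a few compounds, and the source may have more. Where it says the series, first, only, none or still open, it means among the compounds named here.

Compound 1 `COc1cc(NC(C)CCCNC(=O)NNC(=O)Nc2ccc(Cl)cc2)c2ncccc2c1` gives >= 250000 nM in a functional assay on MIA PaCa-2 cells (Homo sapiens) for inhibition, read by MTT assay, with a stated time of 72 h; on this read-out lower numbers stand for stronger inhibition and higher numbers for weaker inhibition.
Compound 2 `COc1cc(NC(C)CCCNC(=O)Nc2cccc(C(F)(F)F)c2)c2ncccc2c1` gives 17000 nM in this assay.
Compound 3 `COc1cc(NC(C)CCCNC(=O)NNC(=O)Nc2cccc(C(F)(F)F)c2)c2ncccc2c1` gives 5600 nM in this assay.

Of the compounds shown here, three have been measured in this assay. Compound 3 gives the lowest number of the three. Compound 2 sits at 17000 nM, a higher number than compound 3 and beyond the scatter. For compound 1 the figure is a limit of the assay, not a number; it is the limit noted as the limit of >= 250000 nM in this assay, at which 1 of the 3 values shown sits.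

The difference between the core of compound 2 and the core of compound 3 is not broken down here. Within the pair of compounds 3 and 1 the change is 4-chlorophenyl in place of 3-(trifluoromethyl)phenyl on an amide-type nitrogen, and it made an at least 44-fold higher number from compound 3 to compound 1 (1.64 log units; beyond the scatter).

Compound 4 `COc1cc(NC(C)CCCNC(=O)Nc2ccc(Cl)cc2)c2ncccc2c1` has not yet been measured in this assay. The change from compound 2 to compound 4 is 4-chlorophenyl in place of 3-(trifluoromethyl)phenyl on an amide-type nitrogen. The place is the same, an amide-type nitrogen whose other neighbour is a carbonyl carbon, so this is the same change as from compound 3 to compound 1. The step from compound 2 to compound 4 is expected to be a 15-fold higher number from compound 2 to compound 4 (1.17 log units; beyond the scatter), a large rise of the same kind, resting on the earlier step of an at least 44-fold higher number from compound 3 to compound 1 (1.64 log units; beyond the scatter). Starting from the higher number of compound 2, the expected result may well be only a limit. For compound 4 the estimate is 250000 nM, with a likely range from 60000 nM to 1000000 nM.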

Compound 4, half-maximal inhibitory concentration: 22000 nM
Compound 4: middle estimate off by 11-fold (1.06 log units), on the high side, and the stated range ends above it.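

In this assay, the change to 4-chlorophenyl in place of 3-(trifluoromethyl)phenyl on an amide-type nitrogen did not carry over from one core to the other: the same change on two cores in this assay, an at least 44-fold higher number (1.64 log units; beyond the scatter) from compound 3 to compound 1 and a 1.3-fold higher number (0.11 log units; within the scatter) from compound 2 to compound 4, at least 34-fold (1.53 log units) apart, beyond the scatter of two such steps. On the core of compound 2 the change gave a 1.3-fold higher number from compound 2 to compound 4 (0.11 log units; within the scatter), so the large penalty seen with the core of compound 3 did not appear there, while the step that keeps 4-chlorophenyl and changes the group on that nitrogen gave an at least 11-fold lower number from compound 1 to compound 4 (1.05 log units; beyond the scatter). Going by these compounds, these pairs show that the effect of this aryl swap depends on the core, but two pairs give no rule for any further core and do not show what sets the difference, and the size of the larger step stays open, as compound 1 stands at a limit of the assay and not at a number: the limit of >= 250000 nM in this assay, at which 1 of the 4 values shown sits.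

The compounds shown leave open how other aryl groups, such as an unsubstituted phenyl, would behave on these two cores. They also leave open whether a longer chain, or an amine or a carboxylic acid on the aryl ring, would widen or close the gap between the two cores.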